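Removing One Methyl from Compound 2: An Expected Inhibition Value

This account rests on a few compounds, and the source may have more. Where it says the series, first, only, none or still open, it means among the compounds named here.

Compounds measured in a functional assay on HeLa cells (Homo sapiens) for inhibition, read by CCK-8 assay, with a stated time of 48 h; a lower number here means a stronger inhibitor, a higher number a weaker inhibitor:
Compound 1 `Cc1ccc(C2=NN(C3=NC(c4ccccc4)CS3)C(c3ccc4ccccc4c3)C2)cc1C` gives 950 nM.
Compound 2 `Cc1ccc(C2=NN(C3=NC(c4ccccc4)CS3)C(c3cccc4ccccc34)C2)cc1C` gives 1720 nM.
Compound 3 `O=C1CSC(N2N=C(c3ccc(Cl)cc3)CC2c2cccc3ccccc23)=N1` gives 8840 nM.

Among these three numbers, compound 2 holds the second highest. Its nearest neighbour is compound 1, which differs by a 1.8-fold higher number from compound 1 to compound 2 (0.26 log units; within the scatter), a step the data call within the scatter. Compound 3 lies furthest away, with a number well beyond the scatter from compound 2.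

The unmeasured compound 4 `Cc1ccc(C2=NN(C3=NC(c4ccccc4)CS3)C(c3cccc4ccccc34)C2)cc1` differs from compound 2 by hydrogen in place of methyl on an aromatic carbon. Among the measured compounds shown here, none of the measured steps touches this change: the only single-place step among the measured compounds swaps the position on the naphthalenyl ring and stayed within the scatter, while compound 3 differs from compound 2 in several places at once. The account therefore has no measured guide for the loss of a methyl group and expects no step beyond the scatter in this assay.

Compound 4 is thus estimated to give 1800 nM, in a range from 700 nM to 5000 nM. That estimate means an expected step of a 1.0-fold higher number from compound 2 to compound 4 (0.02 log units; within the scatter), inside the usual scatter.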

Compound 4, half-maximal inhibitory concentration: 4290 nM
For compound 4 the middle estimate is 2.4-fold (0.38 log units) below the measured one; the range from low to high includes it.
By their numbers in this assay, from the lowest: compounds 1 and 2 (each within the scatter of the next); then compound 4; then compound 3.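

In this assay the change from 3,4-dimethylphenyl to 4-methylphenyl gives a 2.5-fold higher number from compound 2 to compound 4 (0.40 log units; beyond the scatter) and so marks this aromatic carbon, ortho to a methyl group and meta to a large group, as a place where one methyl counts, if modestly. The earlier single-place step, a 1.8-fold higher number from compound 1 to compound 2 (0.26 log units; within the scatter) for the naphthalenyl swap, stayed within the scatter and said nothing about this ring. Nothing available explains why the number rises when this methyl leaves.

The compounds shown leave open what the methyl that remains in compound 4 contributes, and whether the number would move again with that group gone as well. They also leave open how a methoxy group or an amine would read on this same aromatic carbon.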